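The source may hold more compounds than are shown below. What is called first, only, known or untested is meant among the compounds shown, and "the series" means these compounds.

For the measured compounds named here, in a functional assay on K562 cells (Homo sapiens) for cytotoxicity, read by trypan blue exclusion, with a stated time of 96 h (on this read-out higher numbers stand for weaker inhibition and lower numbers for stronger inhibition), compound 1 `COc1ccc(NS(=O)(=O)/C=C/c2c(F)c(F)c(F)c(F)c2F)cc1[N+](=O)[O-]` gives 100000 nM, the highest of the two numbers so far. Compound 2 `COc1ccc(/C=C/S(=O)(=O)Nc2c(F)c(F)c(F)c(F)c2F)cc1N` gives 35000 nM, and the gap between the two lies beyond the usual scatter. Compound 3 `COc1ccc(NS(=O)(=O)/C=C/c2c(F)c(F)c(F)c(F)c2F)cc1` has hydrogen in place of nitro on an aromatic carbon, ortho to a methoxy group: hydrogen in place of nitro on an aromatic carbon. Going by the values given here, no measured pair shows this change, so any expectation is loose. With compound 1 at 100000 nM, a moderate move toward stronger inhibition is expected, an estimated 3.3-fold lower number from compound 1 to compound 3 (0.52 log units; beyond the scatter). For compound 3 the estimated value is 30000 nM, with an expected range from 5000 nM to 100000 nM.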

Compound 3, half-maximal inhibitory concentration: 5000 nM
The estimate for compound 3 lay 6.0-fold (0.78 log units) above the measured number, and the stated range covers the measured number.
By their numbers in this assay, from the lowest: compound 3; then compound 2; then compound 1.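

In this assay, putting hydrogen in place of nitro on this aromatic carbon, ortho to a methoxy group, gives a 20-fold lower number from compound 1 to compound 3 (1.30 log units; beyond the scatter) and so a large move toward stronger inhibition. For the compounds shown here, the two earlier compounds differ in more than one place, so only this pair shows that a change at this single position can move the number so far. Nothing available explains the size of this step. On these data alone, whether a chlorine atom or a carboxylic acid on this carbon would give a number close to that of compound 3 remains open.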